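A few compounds are considered here, and "the series" means these few. Any claim that something is new, unique, unknown or untested is made for them only; others in the source may bear on it.

Measured so far:
- compound 1 `CN1/C(=C/C=C/C2=[N+](CCCc3ccccc3)c3ccccc3C2(C)C)C(C)(C)c2ccccc21` gives 96% in an assay for displacement of a labelled ligand from protein arginine N-methyltransferase 1 (Homo sapiens), read by scintillation proximity assay, with stated times of 5 min and 8 min, tested at 30 uM; on this read-out lower numbers stand for a weaker effect and higher numbers for a stronger effect at the one concentration tested
- compound 2 `CC[N+]1=C(/C=C/C=C2/N(C)c3ccccc3C2(C)C)C(C)(C)c2ccccc21` gives 9% in this assay

Compound 1 stands highest of the two numbers in this assay; its nearest neighbour is compound 2, and the step between them is large: a number 87 percentage points lower from compound 1 to compound 2 (beyond the scatter). That step is the only one measured and it involves the chain on the double-bonded ring nitrogen. Compound 3 `CC1(C)C(/C=C/C=C2/N(CCCc3ccccc3)c3ccccc3C2(C)C)=[N+](CCCc2ccccc2)c2ccccc21` is the not yet measured analogue, differing from compound 1 thus: phenethyl in place of hydrogen on a saturated chain carbon bound to a nitrogen on an aromatic ring in a ring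

Among the measured compounds shown here, this change sits on the other ring nitrogen of the shared core, so the one measured step bears on it only indirectly: it shows that a chain bearing a phenyl on one nitrogen goes with a high reading, while compound 2 with only the short chain there sits low. Compound 1 already sits near the top of the read-out, so little room remains upward; the step from compound 1 to compound 3 is expected to be small or none beyond the scatter, roughly a number 2 percentage points lower from compound 1 to compound 3 (within the scatter). Compound 3 is therefore estimated at 94%, with a range from 78% to 100% in this assay.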

Compound 3, a percentage reported as inhibition, at one concentration (the size of the read-out at that concentration, not a potency): 101%
Compound 3: middle estimate off by 7 percentage points, on the low side; measured number outside the range, above it.
By their numbers in this assay, from the lowest: compound 2; then compounds 1 and 3 (each within the scatter of the next).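

In this assay, the step of a number 5 percentage points higher from compound 1 to compound 3 (within the scatter) shows that this position, on a saturated chain carbon bound to a nitrogen on an aromatic ring in a ring, accepts phenethyl without a change that can be read, so methyl and 3-phenylpropyl read alike here when one 3-phenylpropyl chain is already present. The earlier step, a number 87 percentage points lower from compound 1 to compound 2 (beyond the scatter), showed only that the chain at the other place matters; the new step adds that a second such chain is tolerated, but with compound 1 already at 96% the read-out leaves little room to show a gain. Nothing at hand explains this tolerance.

Still open, on these data alone, is whether this position would accept other groups in place of phenethyl, such as an amine, a carboxylic acid or a longer chain, with the 3-phenylpropyl chain kept on the shared core. As far as these compounds go, since this assay reports one concentration only, whether compound 1 and compound 3 would differ in the size of their effect at other concentrations also remains open, and a read-out at lower concentrations would be needed to separate them.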